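Chain Lengthening of an Isothiocyanate Arm and Cell Inhibition

The source may hold more compounds than are shown below. What is called first, only, known or untested is meant among the compounds shown, and "the series" means these compounds.

The study follows four compounds in a functional assay on NCI-H1299 cells (Homo sapiens) for inhibition, read by CCK-8 assay, with a stated time of 72 h, tested at 1 uM; a lower number here means a weaker effect, a higher number a stronger effect of the compound at the concentration tested. Compound 1 `CN(C)C(=O)c1cc2cnc(Nc3ccc(C(=O)NCCCCCCN=C=S)cc3)nc2n1C1CCCC1` gives 49.4% in this assay, and compound 2 `CN(C)C(=O)c1cc2cnc(Nc3ccc(C(=O)NCCCCCCCN=C=S)cc3)nc2n1C1CCCC1` gives 75.7% there. The difference between them is a group of 4 heavy atoms (2 carbon, 1 nitrogen, 1 sulfur; no ring) in place of a group of 3 heavy atoms (1 carbon, 1 nitrogen, 1 sulfur; no ring), on a saturated chain carbon, six bonds along the chain from an amide-type nitrogen, and it made a step of a number 26.3 percentage points higher from compound 1 to compound 2 (beyond the scatter). Compound 3 `CN(C)C(=O)c1cc2cnc(Nc3ccc(C(=O)NCCCN=C=S)cc3F)nc2n1C1CCCC1` gives 9.27% in this assay, the lowest of the three numbers; how its core differs from that of compound 1 is not broken down here. Compound 4 `CN(C)C(=O)c1cc2cnc(Nc3ccc(C(=O)NCCCCN=C=S)cc3F)nc2n1C1CCCC1` is not yet measured and differs from compound 3 by a group of 4 heavy atoms (2 carbon, 1 nitrogen, 1 sulfur; no ring) in place of a group of 3 heavy atoms (1 carbon, 1 nitrogen, 1 sulfur; no ring), on a saturated chain carbon, three bonds along the chain from an amide-type nitrogen. Among the measured compounds shown here, this is the same kind of change as the one from compound 1 to compound 2, though not the same: there the group sits six bonds along the chain from the amide-type nitrogen, here three bonds along the chain from it. From compound 3 to compound 4 a step of a number 15.7 percentage points higher from compound 3 to compound 4 (beyond the scatter) is expected in this assay, a direction resting on a number 26.3 percentage points higher from compound 1 to compound 2 (beyond the scatter) but taken as smaller given the shorter chain and the different core. Compound 4 is estimated at 25%, between 5% and 50%.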

Compound 4, a percentage reported as inhibition, at one concentration (the size of the read-out at that concentration, not a potency): 28.7%
Estimate against measurement, compound 4: 3.7 percentage points below; measured number inside the range.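

In this assay, lengthening the chain that carries the isothiocyanate on the fluorine-bearing core, with the group of 4 heavy atoms in place of the group of 3 heavy atoms, gave a number 19.4 percentage points higher from compound 3 to compound 4 (beyond the scatter). Set beside the earlier step on the core of compound 1, this shows the same change raising the number on both cores, with no difference in size that can be told apart: the same change on two cores in this assay, a number 26.3 percentage points higher (beyond the scatter) from compound 1 to compound 2 and a number 19.4 percentage points higher (beyond the scatter) from compound 3 to compound 4, 6.9 percentage points apart, within the scatter of two such steps It does not show that the step would hold on any other core or at any other chain length, since the two pairs sit at different places along the chain, and it offers no explanation for the rise.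

The compounds shown leave open whether a still longer chain on the core of compound 3 would raise the number further. They also leave open whether an amine or a carboxylic acid at the end of the chain, in place of the isothiocyanate, would follow the same trend.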